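A few compounds are considered here, and "the series" means these few. Any claim that something is new, unique, unknown or untested is made for them only; others in the source may bear on it.

Three compounds share a core in which a thiol-bearing five-membered heteroaromatic ring carries a pyrazinyl group, and differ only in the group attached through the ring nitrogen. Compound 1 `Sc1nnc(-c2cnccn2)n1/N=C/c1ccccc1` gives 52400 nM in a functional assay, with a stated time of 30 min; a higher number here means a weaker inhibitor, a lower number a stronger inhibitor. Compound 2 `S=C(Nc1ccccc1)Nn1c(S)nnc1-c1cnccn1` gives 58800 nM in this assay, and compound 3 `S=C(Nc1ccc2ccccc2c1)Nn1c(S)nnc1-c1cnccn1` gives 75900 nM. The value of compound 2 lies within the scatter of both compound 1 and compound 3, so no difference among the three can be claimed. Compound 4 `S=C(Nc1ccc(Cl)cc1)Nn1c(S)nnc1-c1cnccn1` differs from compound 2 in one place: chloro in place of hydrogen on an aromatic carbon. Since the change from phenyl to naphthyl between compound 2 and compound 3 left the values within scatter, the step of a 1.1-fold lower number from compound 2 to compound 4 (0.03 log units; within the scatter) is expected to stay within the scatter as well. Compound 4 is therefore estimated at 55000 nM, with a range from 25000 nM to 120000 nM.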

Compound 4, half-maximal inhibitory concentration: 75900 nM
Compound 4: middle estimate off by 1.4-fold (0.14 log units), on the low side; low and high end bracket the measured number.
By their numbers in this assay, from the lowest: compounds 1, 2, 3 and 4 (each within the scatter of the next).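

Going from phenyl to 4-chlorophenyl gives a 1.3-fold higher number from compound 2 to compound 4 (0.11 log units; within the scatter) in this assay and is the first change in a single place that can be read in this set. On this aromatic carbon, para to a large group, chloro in place of hydrogen therefore brings no difference that can be claimed. Nothing available bears on why this is so. As far as these compounds go, whether an amine, a carboxylic acid or a methoxy group at this position would take the number beyond the scatter remains open.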